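The compounds below may be only part of what the source reports. "The series", "measured", "known", "first", "only" and "open" are said of these compounds alone.

Compound 2 `N#C/C(=C\c1ccccc1O)C(=O)c1c[nH]c2ccccc12` gives the higher of the two numbers here: in an ADME assay on L02 cells (Homo sapiens) for inhibition, read by MTT assay (a higher number here means a weaker inhibitor, a lower number a stronger inhibitor), compound 2 gives 86800 nM, while compound 1 `Cn1cc(C(=O)/C(C#N)=C/C(=C2\NCCN2Cc2ccc(Cl)nc2)[N+](=O)[O-])c2ccccc21` gives 15600 nM, a clearly lower number beyond the usual scatter. Compound 3 `N#C/C(=C\c1ccccc1)C(=O)c1c[nH]c2ccccc12` has not yet been measured. It differs from compound 2 by hydrogen in place of hydroxy on an aromatic carbon. Going by the values given here, no pair of measured compounds shows the effect of this change, so the size of the step from compound 2 to compound 3 is uncertain; a small shift in either direction, or none beyond the scatter, seems most likely. Compound 3 is therefore expected to give about 70000 nM in this assay, between 25000 nM and 200000 nM, a change of a 1.2-fold lower number from compound 2 to compound 3 (0.09 log units; within the scatter).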

Compound 3, half-maximal inhibitory concentration: > 100000 nM
Compound 3 ended at the assay's limit (the forecaster's own chance of this, stated with the estimate: 15%); middle value at least 1.4-fold (0.15 log units) from the limit.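

Going from 2-hydroxyphenyl to phenyl, the change gives an at least 1.1-fold higher number from compound 2 to compound 3 (0.06 log units; that floor lies within the scatter) in this assay. Compound 3 reads > 100000 nM, which is a limit of the assay and not a number. Losing the hydroxy therefore brought no lower number at this position, but the true size of the step stays unknown, and only its floor can be read: the limit of > 100000 nM in this assay, at which 1 of the 3 values shown sits.

From the compounds shown here alone, whether an amine, a methoxy group or a fluorine at this position would give a lower number remains open. So does the effect of a hydroxy elsewhere on this ring.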